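Swapping 4-hydroxyphenyl for 3,4-dimethoxyphenyl in a growth inhibitor

The compounds below may be only part of what the source reports. "The series", "measured", "known", "first", "only" and "open" are said of these compounds alone.

In a functional assay on A549 cells (Homo sapiens) for inhibition, read by sulforhodamine B assay (a higher number here means a weaker inhibitor of growth, a lower number a stronger inhibitor of growth), compound 1 (`Oc1cccc2[nH]c(-c3ccc(-c4ccc(-c5ccccc5)cc4)cc3)nc12`) stands at 8320 nM and serves as the starting point here. Compound 2 (`Oc1cccc2[nH]c(-c3ccc(-c4ccc(-c5ccc(OC(F)(F)F)cc5)cc4)cc3)nc12`) reaches 190 nM and compound 3 (`Oc1ccc(-c2ccc(-c3ccc(-c4nc5c(O)cccc5[nH]4)cc3)cc2)cc1`) reaches 170 nM on the same scale. Compound 3 sits level with compound 2, as a 1.1-fold lower number from compound 2 to compound 3 (0.05 log units; within the scatter) lies within the scatter, and both stand far under compound 1. The two large steps are a 44-fold lower number from compound 1 to compound 2 (1.64 log units; beyond the scatter) with trifluoromethoxy and a 49-fold lower number from compound 1 to compound 3 (1.69 log units; beyond the scatter) with hydroxy, each in place of hydrogen on an aromatic carbon.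

Compound 4 (`COc1ccc(-c2ccc(-c3ccc(-c4nc5c(O)cccc5[nH]4)cc3)cc2)cc1OC`) alters compound 3 once more (3,4-dimethoxyphenyl in place of 4-hydroxyphenyl on an aromatic carbon): 3,4-dimethoxyphenyl in place of 4-hydroxyphenyl, para to a large group. Among the compounds with values here, no measured compound carries this group, so the data offer no direct test. Still, two quite different groups gave level numbers in compound 2 and compound 3, and compound 4 keeps a substituted ring rather than the bare one of compound 1. No step beyond the scatter is therefore expected in this assay, with a slight lean towards a higher number. An estimated 1.6-fold higher number from compound 3 to compound 4 (0.22 log units; within the scatter) is what this expectation means in numbers. For compound 4 the estimate is 280 nM with an expected range from 90 nM to 900 nM around it.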

Compound 4, concentration for 50% growth inhibition: 1310 nM
Estimate against measurement, compound 4: 4.7-fold (0.67 log units) below; measured number above the stated range.
By their numbers in this assay, from the lowest: compounds 3 and 2 (each within the scatter of the next); then compound 4; then compound 1.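

Until now, the two substituted rings at this position had given values within the scatter of each other, which could suggest that almost any substituent on the outer ring serves equally well. The 3,4-dimethoxyphenyl ring ends that reading in this assay, with a 7.7-fold higher number from compound 3 to compound 4 (0.89 log units; beyond the scatter) and with a 6.9-fold higher number from compound 2 to compound 4 (0.84 log units; beyond the scatter) as the matching step from the other substituted ring. It still keeps part of the gain over the bare phenyl ring, as a 6.4-fold lower number from compound 1 to compound 4 (0.80 log units; beyond the scatter) shows, so these substituted rings all improve on phenyl, but not to one common level, and nothing available here explains the difference between them.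

Compound 4 replaces the hydroxy group with methoxy and adds a second methoxy group in a single change, so the compounds shown leave open which of the two accounts for the higher number. A ring with a single methoxy group could separate these two parts, and an amine or a carboxylic acid on the outer ring would show how far the level seen with hydroxy and trifluoromethoxy extends to other groups.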